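Compound 3 to compound 4: swapping the benzyl substituent

The source may hold more compounds than are shown below. What is called first, only, known or untested is meant among the compounds shown, and "the series" means these compounds.

In a functional assay on HL-60 cells (Homo sapiens) for cytotoxicity, read by WST assay, with a stated time of 48 h (a higher number here means that more compound is needed for the effect, a lower number that less compound is needed), compound 1 `O=C1OC[C@H](Cc2cccc(O)c2)[C@H]1Cc1ccc(Cl)c(Cl)c1` gives 48000 nM, compound 2 `Cc1ccc(C[C@H]2COC(=O)[C@@H]2Cc2ccc(Cl)c(Cl)c2)cc1` gives 19000 nM and compound 3 `CCc1ccc(C[C@H]2COC(=O)[C@@H]2Cc2ccc(Cl)c(Cl)c2)cc1` gives 16000 nM. Compound 3 therefore shares the low end of these numbers with compound 2, as a 1.2-fold lower number from compound 2 to compound 3 (0.07 log units; within the scatter) shows. Compound 4 `O=C1OC[C@H](Cc2ccc(F)c(F)c2)[C@H]1Cc1ccc(Cl)c(Cl)c1` brings (3,4-difluorophenyl in place of 4-ethylphenyl on a saturated chain carbon bound to a saturated ring carbon), with 3,4-difluorophenyl in place of 4-ethylphenyl on a saturated chain carbon bound to a saturated ring carbon. Within the data shown here, no measured step introduces fluorine. The nearest guides are the modest steps at this place, a 2.5-fold lower number from compound 1 to compound 2 (0.40 log units; beyond the scatter) and a 3.0-fold lower number from compound 1 to compound 3 (0.48 log units; beyond the scatter). Only a small step to a higher number is therefore expected in this assay, probably within the scatter. The expected change is a 1.5-fold higher number from compound 3 to compound 4 (0.18 log units; within the scatter). Compound 4 is estimated at 24000 nM, with an expected range of 10000 nM to 55000 nM.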

Compound 4, half-maximal effective concentration: 25000 nM
Compound 4: the middle estimate sits 1.0-fold (0.02 log units) below what was measured; the range from low to high includes it.
By their numbers in this assay, from the lowest: compounds 3, 2, 4 and 1 (each within the scatter of the next, the first and the last beyond it).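

On a saturated chain carbon bound to a saturated ring carbon, 3,4-difluorophenyl stays within the scatter of 4-ethylphenyl, with a 1.6-fold higher number from compound 3 to compound 4 (0.19 log units; within the scatter), and of 4-methylphenyl, with a 1.3-fold higher number from compound 2 to compound 4 (0.12 log units; within the scatter). Unlike those two groups, it also stays within the scatter of 3-hydroxyphenyl, with a 1.9-fold lower number from compound 1 to compound 4 (0.28 log units; within the scatter). Nothing on hand accounts for these steps.

Open, on these data alone, is whether an amine or a carboxylic acid on this phenyl would give a step beyond the scatter. As far as these compounds go, a chain longer than ethyl also remains open.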